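The compounds below may be only part of what the source reports. "The series", "measured", "known", "first", "only" and "open" are said of these compounds alone.

Compound 1, `Cc1nnc(SCc2cc(=O)c3cc(Cl)ccc3o2)o1`, was examined in a functional assay on MCF7 cells (Homo sapiens) for cytotoxicity, read by MTT assay, with a stated time of 72 h; a higher number here means a weaker inhibitor, a lower number a stronger inhibitor. In this assay compound 1 gives only a limit, > 25000 nM, and not a number. Compound 2, `Cc1ccc2oc(CSc3nc(C)cc(C)n3)cc(=O)c2c1`, belongs to the same set. In this assay compound 2 likewise gives only a limit, > 25000 nM. For the measured compounds named here, compound 1 therefore stands at the limit, and the one other value shown stands there as well: the limit of > 25000 nM in this assay, at which 2 of the 2 values shown sit. Going by the values given here, no two measured compounds differ in a single place, so no measured step is available to gauge what a change on the shared core does in this assay.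

Compound 3, `Nc1nnc(SCc2cc(=O)c3cc(Cl)ccc3o2)s1`, has not yet been measured. It differs from compound 1 by 5-amino-1,3,4-thiadiazol-2-yl in place of 5-methyl-1,3,4-oxadiazol-2-yl on a sulfur; in words, 5-amino-1,3,4-thiadiazol-2-yl in place of 5-methyl-1,3,4-oxadiazol-2-yl on a sulfur. Among the compounds with values here, nothing among the measured compounds shows that a change of this kind on the shared core moves potency in this assay beyond the scatter, so the step expected there, a step that the limit leaves unreadable from compound 1 to compound 3, is none beyond the scatter. Compound 3 is accordingly expected to give about 30000 nM in this assay, within a range from 8000 nM to 100000 nM, and most likely again as a limit rather than a number.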

Compound 3, half-maximal inhibitory concentration: > 25000 nM
Compound 3 was reported as a limit; the forecaster's own chance of this, stated with the estimate: 75%; the middle value is on the limit's open side.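

Compound 1 and compound 3 each give only a limit in this assay, so no step between them can be read: the limit of > 25000 nM in this assay, at which 3 of the 3 values shown sit.

The compounds shown leave open whether 5-amino-1,3,4-thiadiazol-2-yl in place of 5-methyl-1,3,4-oxadiazol-2-yl on a sulfur alters potency at all, and whether any change on the shared core would give a measurable number in this assay.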